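The source may report more compounds than this note shows. Statements on the series, on what has been measured and on what is new or still open speak of the compounds shown alone.

Working notes on three compounds of one series. Compound 1 `Cc1ccc(COc2ccc(C(=O)/C=C/c3ccccc3)cc2)cc1` in a functional assay on HCT-116 cells (Homo sapiens) for antiproliferative activity, read by sulforhodamine B assay, with a stated time of 3 days, tested at 50 uM (on this read-out lower numbers stand for a weaker effect and higher numbers for a stronger effect at the one concentration tested), gives "not determined" (no result reported), so no number stands for it. For the measured compounds named here, compound 2 `Cc1ccc(COc2ccc(C(=O)/C=C/c3ccc(F)cc3)cc2)cc1` in this assay gives 15.4%; this is the only number the series holds, and compound 2 therefore stands alone, with compound 1 adding nothing to compare against. Compound 3 `Cc1ccc(COc2ccc(C(=O)/C=C/c3ccc(Cl)cc3)cc2)cc1` is the next entry and is yet to be measured in this assay. It differs from compound 2 by chloro in place of fluoro on an aromatic carbon. Going by the values given here, no step between two measured compounds exists, so nothing measured shows how a change of this kind moves this assay. The expected step from compound 2 to compound 3 is a number 4.6 percentage points higher from compound 2 to compound 3 (within the scatter), a small rise that is not expected to reach beyond the scatter. Compound 3 in this assay is estimated at 20%, within 5% to 40%.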

Compound 3, a percentage reported as inhibition, at one concentration (the size of the read-out at that concentration, not a potency): 16.9%
Compound 3: the middle estimate sits 3.1 percentage points above what was measured, and the stated range covers the measured number.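

In this assay, for the compounds shown here, chloro in place of fluoro on an aromatic carbon gives a number 1.5 percentage points higher from compound 2 to compound 3 (within the scatter), the first step that can be read. At this position, para to a large group, the change from 4-fluorophenyl to 4-chlorophenyl therefore does not separate compound 2 from compound 3 on this read-out, at the one concentration tested. No supporting data bear on this result.

On these data alone, compound 1 gives "not determined" (no result reported), so how either halogen compares with the unsubstituted phenyl of the core of compound 1 remains open. Also open, as far as these compounds go, is whether a group of another kind at this position, such as an amine, a carboxylic acid or a longer alkyl chain, would give a step beyond the scatter.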